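Swapping the aryl group on a fused core: cytotoxicity outlook

The source may report more compounds than this note shows. Statements on the series, on what has been measured and on what is new or still open speak of the compounds shown alone.

Measured so far in an ADME assay on Huh-7 cells (Homo sapiens) for cytotoxicity, read by MTT assay, with a stated time of 48 h; on this read-out higher numbers stand for lower toxicity in this test and lower numbers for higher toxicity in this test:
compound 1 `CN(C)CCCCC(=O)Nc1ccc(CN2N=C(c3ccc(F)cc3)C3C=CC=CC3C2=O)cc1` gives 77700 nM
compound 2 `CCCCOC(=O)Nc1ccc(CN2N=C(c3ccc(F)cc3)C3C=CC=CC3C2=O)cc1` gives 19500 nM
compound 3 `CN(C)CCCCOC(=O)Nc1ccc(Cn2nc(-c3ccc(C(F)(F)F)cc3)c3ccccc3c2=O)cc1` gives 3360 nM

Compound 3 stands lowest of the three numbers, so it is the most toxic in this test; compound 2 sits nearest to it and compound 1 furthest, both with higher numbers. For the measured compounds named here, the only single-point step among the measured compounds is a 4.0-fold lower number from compound 1 to compound 2 (0.60 log units; beyond the scatter), where the change sits on a carbonyl carbon and the shared core stays untouched. Compound 4 `COc1ccccc1-c1nn(Cc2ccc(NC(=O)OCCCCN(C)C)cc2)c(=O)c2ccccc12` differs from compound 3 at a different place: 2-methoxyphenyl in place of 4-(trifluoromethyl)phenyl on an aromatic carbon. Going by the values given here, no measured pair varies this aryl group, so that single step gives no guide on direction here; it only shows that one exchange of a group on this shared core can move this assay beyond the scatter. Among the compounds with values here, with no bearing step, a change within the scatter is expected, and the range is set wide on both sides. Compound 4 is therefore estimated at 4500 nM, between 1300 nM and 16000 nM, an expected step of a 1.3-fold higher number from compound 3 to compound 4 (0.13 log units; within the scatter).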

Compound 4, half-maximal cytotoxic concentration: 44800 nM
The estimate for compound 4 lay 10-fold (1.00 log units) below the measured number; the whole stated range lies below it.
By their numbers in this assay, from the lowest: compound 3; then compound 2; then compounds 4 and 1 (each within the scatter of the next).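

In this assay, placing 2-methoxyphenyl where 4-(trifluoromethyl)phenyl stood gives a 13-fold higher number from compound 3 to compound 4 (1.12 log units; beyond the scatter), so this aromatic carbon, next to the ring nitrogen, is a place where exchanging the aryl group alone can shift the read-out strongly, here toward lower toxicity in this test. The two aryl groups differ both in their substituent and in where it sits on the phenyl ring, so this single step cannot separate those two changes. Nothing available explains the size of this step.

The compounds shown leave open whether the methoxy group itself or its place on the phenyl ring carries the step, a question that 4-methoxyphenyl or plain phenyl at this carbon would help settle. On these data alone, how a 2-chlorophenyl or a 2-aminophenyl would read here also remains open.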